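Removing the bromo group from compound 2

A few compounds are considered here, and "the series" means these few. Any claim that something is new, unique, unknown or untested is made for them only; others in the source may bear on it.

Compound 1 `CCCCCCCCOc1cc(OC)c(Br)cc1C(C)=O`: 30900000 nM
Compound 2 `CCCCCCCCCCOc1cc(OC)c(Br)cc1C(C)=O`: 15000000 nM

In a functional assay, with stated times of 30 s and 6 min, in the presence of a further agent that is not named here (a lower number here means a stronger inhibitor, a higher number a weaker inhibitor), compound 2 gives the lower of the two numbers, 15000000 nM. Compound 3 `CCCCCCCCCCOc1cc(OC)ccc1C(C)=O` carries hydrogen in place of bromo on an aromatic carbon. Within the data shown here, no measured step touches this group. The only one, a 2.1-fold lower number from compound 1 to compound 2 (0.31 log units; beyond the scatter), concerns the chain and offers no more than a rough scale. Only a small move toward a higher number is therefore expected, and the estimated step is a 1.7-fold higher number from compound 2 to compound 3 (0.22 log units; within the scatter). Compound 3 is expected at 25000000 nM, with an estimated range of 8000000 nM to 70000000 nM.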

Compound 3, half-maximal inhibitory concentration: 26600000 nM
Compound 3: middle estimate off by 1.1-fold (0.03 log units), on the low side; measured number inside the range.
By their numbers in this assay, from the lowest: compounds 2, 3 and 1 (each within the scatter of the next, the first and the last beyond it).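

In this assay, hydrogen in place of bromo on this aromatic carbon gives a 1.8-fold higher number from compound 2 to compound 3 (0.25 log units; within the scatter), so the bromo group, the first part of the shared core to be varied, is not shown to be needed for the number seen with compound 2. The data on hand give no explanation for this result.

As far as these compounds go, whether an amine, a carboxylic acid or a nitrile on this carbon would separate from compound 2 stays open. So does whether the same replacement would read alike on the chain of compound 1.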